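Propoxy for isobutylamino on an acyclic nucleoside core

The source may report more compounds than this note shows. Statements on the series, on what has been measured and on what is new or still open speak of the compounds shown alone.

Compound 1 `Nc1nc(NC2CC2)c2ncn(/C=C3/CC3(CO)CO)c2n1` has been tested in an ADME assay on MOLT-3 cells (Homo sapiens) for cytotoxicity, with a stated time of 7 days; on this read-out higher numbers stand for lower toxicity in this test and lower numbers for higher toxicity in this test; compound 1 gives a limit rather than a number there, > 20000 nM, since the scale of the test reaches only that far. For compound 2 `CC(C)CNc1nc(N)nc2c1ncn2/C=C1/CC1(CO)CO` the entry in this assay reads "not determined" (no result reported), so compound 2 stands without a number of its own. Within the data shown here, the only value shown for the pair is the limit of > 20000 nM in this assay, at which 1 of the 2 values shown sits. Compound 3 `CCCOc1nc(N)nc2c1ncn2/C=C1/CC1(CO)CO` has not yet been measured in this assay. The change from compound 2 to compound 3 is propoxy in place of isobutylamino on an aromatic carbon. No measured pair among these compounds shows how such a change shifts the read-out. The expectation for compound 3 therefore rests on compound 1 alone, whose reading is a limit, so compound 3 is expected to sit at or around the same limit, with any true difference from compound 1 likely within the usual scatter. Compound 3 is estimated at 20000 nM, within 8000 nM to 50000 nM.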

Compound 3, half-maximal cytotoxic concentration: > 20000 nM
Compound 3: only a limit was reported; the forecaster's own chance of this, stated with the estimate: 80%; the middle value sits exactly at the limit.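

Among these compounds, compound 1 and compound 3 each give only a limit, not a number, so no step between them can be read: the limit of > 20000 nM in this assay, at which 2 of the 3 values shown sit.
Still open, as far as these compounds go, is whether compound 1, compound 2 and compound 3 differ at all in toxicity to these cells, and whether swapping isobutylamino for propoxy shifts the read-out.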